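The source may hold more compounds than are shown below. What is called first, only, known or untested is meant among the compounds shown, and "the series" means these compounds.

Notes on the shared core. Compound 1 `CCOC(=O)C1=Cc2ccccc2OC1(OCc1cc(-c2ccc(F)cc2F)no1)C(F)(F)F` bears a 2,4-difluorophenyl group on an aromatic carbon of a five-membered aromatic ring with 1 nitrogen and 1 oxygen. In a functional assay on DU-145 cells (Homo sapiens) for inhibition, read by MTT assay, with a stated time of 24 h (a lower number here means a stronger inhibitor, a higher number a weaker inhibitor), compound 1 gives only a limit, > 150000 nM. Compound 2 `CCOC(=O)C1=Cc2ccccc2OC1(OCc1cn(CC(=O)Nc2ccc(OC)cc2)nn1)C(F)(F)F` gives 32700 nM in this assay. Compound 3 `CCOC(=O)C1=Cc2ccccc2OC1(OCc1cn(-c2ccccc2)nn1)C(F)(F)F` gives only a limit, > 150000 nM. Among the compounds with values here, the single measured step, an at least 4.5-fold higher number from compound 2 to compound 3 (0.66 log units; beyond the scatter), concerns an aromatic nitrogen of a different ring and does not bear on the change at hand; that two of the three values sit at the limit of > 150000 nM in this assay, at which 2 of the 3 values shown sit, shows where compound 1 stands. Compound 4 `CCOC(=O)C1=Cc2ccccc2OC1(OCc1cc(-c2ccc(OC)cc2)no1)C(F)(F)F` differs from compound 1 by 4-methoxyphenyl in place of 2,4-difluorophenyl on an aromatic carbon. Within the data shown here, no measured step tests this swap, so only a modest and uncertain step an at least 1.5-fold lower number from compound 1 to compound 4 (0.17 log units; that floor lies within the scatter) is expected. Compound 4 is expected to give about 100000 nM, between 20000 nM and 300000 nM.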

Compound 4, half-maximal inhibitory concentration: > 150000 nM
Compound 4 was reported as a limit; the forecaster's own chance of this, stated with the estimate: 55%; at least 1.5-fold (0.17 log units) between middle value and limit.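

Within the data shown here, compound 1 and compound 4 both stand only as limits, so no step between them can be read: the limit of > 150000 nM in this assay, at which 3 of the 4 values shown sit.

As far as these compounds go, whether 4-methoxyphenyl in place of 2,4-difluorophenyl changes inhibition at all remains open.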